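Notes on swapping the 4-ethylpiperidinyl group for butoxy

This account rests on a few compounds, and the source may have more. Where it says the series, first, only, none or still open, it means among the compounds named here.

Within the data shown here, compound 2 `CCC1CCN(c2nc(C(C)(C)C)ccc2CNC(=O)C(C)c2ccc(NS(C)(=O)=O)c(F)c2)CC1` gives 0.1 nM in an assay on cells for antagonist activity at transient receptor potential cation channel subfamily V member 1 (Homo sapiens), read by FLIPR and calcium flux, with a stated time of 6 min (a lower number here means a stronger inhibitor, a higher number a weaker inhibitor), the lowest of the two numbers measured so far; compound 1 `CC(C(=O)NCc1ccc(C(C)(C)C)nc1N1CCCCCC1)c1ccc(NS(C)(=O)=O)c(F)c1` gives 0.9 nM in this assay. Among the measured compounds shown here, the only step in hand, a 9.0-fold lower number from compound 1 to compound 2 (0.95 log units; beyond the scatter), shows that the group next to the ring nitrogen matters, but it exchanges one ring for another. Compound 3 `CCCCOc1nc(C(C)(C)C)ccc1CNC(=O)C(C)c1ccc(NS(C)(=O)=O)c(F)c1` carries a different change: butoxy in place of 4-ethylpiperidin-1-yl on an aromatic carbon. For the measured compounds named here, no measured step covers a ring-to-chain exchange at this position, so the direction is uncertain; a moderate loss is expected, a 10-fold higher number from compound 2 to compound 3 (1.00 log units; beyond the scatter). Compound 3 is therefore estimated at 1 nM, within 0.2 nM to 6 nM.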

Compound 3, inhibition constant: 0.9 nM
The estimate for compound 3 lay 1.1-fold (0.05 log units) above the measured number, and the stated range covers the measured number.
By their numbers in this assay, from the lowest: compound 2; then compounds 1 and 3 (each within the scatter of the next).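

In this assay butoxy in place of 4-ethylpiperidin-1-yl gives a 9.0-fold higher number from compound 2 to compound 3 (0.95 log units; beyond the scatter) while butoxy in place of azepan-1-yl gives no change at the digits printed from compound 1 to compound 3 (within the scatter) and neither of these steps needs further qualification. A ring at this position is therefore not needed to reach the level of compound 1, and of the three groups only 4-ethylpiperidin-1-yl stands apart. Nothing available explains this difference between the groups. Open, as far as these compounds go, is whether a longer chain such as hexyloxy holds the level of butoxy. Also open, from the compounds shown here alone, is whether an open-chain amine such as butylamino does.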